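Adding chlorine to the methylphenyl ether of compound 3

The compounds below may be only part of what the source reports. "The series", "measured", "known", "first", "only" and "open" are said of these compounds alone.

Compound 3 `Cc1ccc(OCc2nc(N)nc(N3CCN(C)CC3)n2)cc1` gives 16100 nM in an assay on HEK293 cells for displacement of a labelled ligand from 5-hydroxytryptamine receptor 7 (Homo sapiens), read by radioligand binding, with a stated time of 1 h (a lower number here means a stronger inhibitor, a higher number a weaker inhibitor), the highest of the three measured numbers. Compound 2 `Cc1ccccc1OCc1nc(N)nc(N2CCN(C)CC2)n1` gives 514 nM, and compound 1 `CN1CCN(c2nc(N)nc(COc3ccccc3Cl)n2)CC1` gives 9250 nM. Compound 4 `Cc1cc(Cl)ccc1OCc1nc(N)nc(N2CCN(C)CC2)n1` carries 4-chloro-2-methylphenyl in place of 4-methylphenyl on an oxygen on a saturated carbon. The step that bears most directly on this change is a 31-fold higher number from compound 2 to compound 3 (1.50 log units; beyond the scatter), since compound 4 restores the 2-methyl that compound 3 lacks. The step of an 18-fold lower number from compound 1 to compound 2 (1.26 log units; beyond the scatter) shows that exchanging one small group at that spot can also move the number widely. Among the compounds with values here, no measured pair tests the extra chlorine, so part of the change is uncertain. A large drop is therefore expected, roughly a 16-fold lower number from compound 3 to compound 4 (1.21 log units; beyond the scatter). Compound 4 is estimated at 1000 nM, within 200 nM to 6000 nM.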

Compound 4, inhibition constant: 15200 nM
Compound 4: middle estimate off by 15-fold (1.18 log units), on the low side; measured number above the stated range.
By their numbers in this assay, from the lowest: compound 2; then compounds 1, 4 and 3 (each within the scatter of the next).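

Restoring the 2-methyl does not help when the chloro comes with it, leaving these two compounds level in this assay (a 1.1-fold lower number from compound 3 to compound 4 (0.02 log units; within the scatter)). The chloro in place of hydrogen on an aromatic carbon is a large loss on its own (a 30-fold higher number from compound 2 to compound 4 (1.47 log units; beyond the scatter)), so among these compounds the low number of compound 2 belongs to the ring without chloro. Compound 4 also sits level with the 2-chlorophenyl ether (a 1.6-fold higher number from compound 1 to compound 4 (0.22 log units; within the scatter)).

No supporting measurement explains the chloro's effect. From the compounds shown here alone, whether fluoro or methoxy in its place would cost as much remains open.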